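Replacing the Urea with Benzylcarbamoyl on the Shared Core

The source may report more compounds than this note shows. Statements on the series, on what has been measured and on what is new or still open speak of the compounds shown alone.

Compound 1 `COCCNC(=O)Nc1nc(C(C)(C)NC(=O)OCc2ccccc2)nc(O)c1O` gives > 500000 nM in an ADME assay on C8166 cells (Homo sapiens) for cytotoxicity, read by MTT assay, with a stated time of 3 days (a higher number here means that more compound is tolerated, a lower number that less compound is tolerated), a limit of the assay rather than a number.
Compound 2 `CC(C)(NC(=O)OCc1ccccc1)c1nc(O)c2oc(=O)[nH]c2n1` gives > 500000 nM in this assay, again a limit.
Compound 3 `COc1ccc(CNC(=O)Nc2nc(C(C)(C)NC(=O)OCc3ccccc3)nc(O)c2O)cc1` gives > 500000 nM in this assay, also a limit.

For the measured compounds named here, compound 1 therefore stands nowhere on a scale: its value is a limit, and the two other values shown are limits as well, so no compound can be placed above or below another. Going by the values given here, the only step between compounds that differ in one place, a step that the two limits leave unreadable from compound 1 to compound 3, cannot be read because both of its ends sit at the limit of > 500000 nM in this assay, at which 3 of the 3 values shown sit.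

Compound 4 `CC(C)(NC(=O)OCc1ccccc1)c1nc(O)c(O)c(C(=O)NCc2ccccc2)n1` is the unmeasured member. It differs from compound 1 by benzylcarbamoyl in place of ((2-methoxyethyl)carbamoyl)amino on an aromatic carbon. Among the compounds with values here, no measured step touches this change, and the one step that exists gives no size at all. Within the data shown here, the only guidance is that every value so far sits at the limit of > 500000 nM in this assay, at which 3 of the 3 values shown sit, which points to compound 4 sitting there as well. Compound 4 is therefore expected at 500000 nM, with a range from 150000 nM to 1500000 nM. The expected step of a number no higher from compound 1 to compound 4 (the limit leaves the size open) is none beyond the scatter, and most likely the assay will again report only a limit.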

Compound 4, half-maximal cytotoxic concentration: 41400 nM
Compound 4: the middle estimate sits 12-fold (1.08 log units) above what was measured; measured number below the stated range.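

Putting benzylcarbamoyl in place of ((2-methoxyethyl)carbamoyl)amino on an aromatic carbon gives an at least 12-fold lower number from compound 1 to compound 4 (1.08 log units; beyond the scatter) in this assay and so marks this position as the first place in the set where a change means that less compound is tolerated. Compound 4 also gives the set its first true number on a scale, while the other compounds stay at a limit: the limit of > 500000 nM in this assay, at which 3 of the 4 values shown sit.

The change is not a single small edit: the entering group brings a six-membered aromatic ring of carbon only and 1 hydrogen-bond donor, the leaving group has no ring and 2 hydrogen-bond donors, and these differences arrive together, so the step alone cannot separate them.

Going by these compounds, the true size of the drop stays open, since one end of the step is a limit, and so does the question of which part of benzylcarbamoyl matters. For the compounds shown here, a simple amine, a carboxylic acid or a longer carbon chain on the same aromatic carbon would show whether any replacement of ((2-methoxyethyl)carbamoyl)amino lowers the number or only one carrying the benzyl ring does.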